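Replacing the hydroxymethyl of compound 3 with a sulfur-bearing group

The source may report more compounds than this note shows. Statements on the series, on what has been measured and on what is new or still open speak of the compounds shown alone.

Measured compounds in an ADME assay on L1210/0 cells (Mus musculus) for cytotoxicity, with a stated time of 48 h; on this read-out lower numbers stand for stronger inhibition and higher numbers for weaker inhibition:
- compound 1, `OC[C@@H]1C[C@H](Cn2cnc3c(NC4CC4)ncnc32)c2c(-c3ccccc3)nnc(-c3ccccc3)c21`: compound 1 gives > 200000 nM, which is a limit of the assay and not a number.
- compound 2, `O=C1O/C(=C\Cn2cc(Br)c(=O)[nH]c2=O)C(OCc2ccccc2)=C1OCc1ccccc1`: compound 2 gives 7500 nM.
- compound 3, `O=c1[nH]c(=O)n([C@H]2C[C@H](O)[C@@H](CO)O2)cc1CO`: compound 3 gives 9180 nM.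

Compound 3 and compound 2 sit within the usual scatter of each other in this assay, so the numbers do not separate them. Compound 1 is the one case that stops at a limit, as recorded in the limit of > 200000 nM in this assay, at which 1 of the 3 values shown sits.

The account now follows the step from compound 3 to compound 4, whose structure is `C[S+]([O-])c1cn([C@H]2C[C@H](O)[C@@H](CO)O2)c(=O)[nH]c1=O`. The change is a group of 3 heavy atoms (1 carbon, 1 oxygen, 1 sulfur; no ring) in place of a group of 2 heavy atoms (1 carbon, 1 oxygen; no ring), on an aromatic carbon. The departing hydroxymethyl carries a hydrogen-bond donor; the entering group carries none, and it adds a sulfur.

Within the data shown here, no measured step between close neighbours exists among the three compounds, so nothing fixes the size of this step in this assay. The expectation is a small shift toward a higher number, on the edge of the scatter rather than clearly beyond it, with the step from compound 3 to compound 4 expected to be a 1.6-fold higher number from compound 3 to compound 4 (0.21 log units; within the scatter). Compound 4 is therefore estimated at 15000 nM, expected to fall between 4000 nM and 60000 nM.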

Compound 4, half-maximal inhibitory concentration: > 200000 nM
Compound 4 was reported as a limit; the forecaster's own chance of this, stated with the estimate: 10%; middle value at least 13-fold (1.12 log units) away from the limit.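

Among these compounds, on the aromatic carbon two atoms from the ring nitrogen, exchanging the hydroxymethyl for the sulfur-bearing group gives the first step between close neighbours in this assay, and it is large: an at least 21-fold higher number from compound 3 to compound 4 (1.33 log units; beyond the scatter). Compound 4 gives > 200000 nM, which is a limit of the assay and not a number, and it joins compound 1 in stopping there: the limit of > 200000 nM in this assay, at which 2 of the 4 values shown sit. Among the compounds shown here, this position, on which the earlier compounds offered no step at all, is therefore far from indifferent to the group it carries, at least for this one exchange on the core of compound 3.

For the compounds shown here, the single step leaves unsettled which part of the change matters, since the hydrogen-bond donor of the hydroxymethyl leaves and a sulfur enters in the same move. A methoxymethyl group, which would lose that donor without adding sulfur, and a methylthio group, which would keep the sulfur without the oxygen on it, would pull these two parts apart, while a small group such as an amine at this carbon would show how far the large step extends beyond this pair.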